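Swapping Hydroxy for Amino on a Double-Bonded Nitrogen

The compounds below may be only part of what the source reports. "The series", "measured", "known", "first", "only" and "open" are said of these compounds alone.

In a functional assay on HL-60 cells (Homo sapiens) for cytotoxicity, read by XTT assay, with a stated time of 72 h (on this read-out higher numbers stand for weaker inhibition and lower numbers for stronger inhibition), compound 1 (`CCn1ccc2cc(C(O)c3ccc(OC)c(OC)c3OC)ccc21`) reports > 10000 nM as a limit of the assay, not a number. For the measured compounds named here, compound 2 (`CCn1ccc2cc(/C(=N/O)c3ccc(OC)c(OC)c3OC)ccc21`) gives 2000 nM as the only true number so far, so it is the sole measured starting point. Compound 3 (`CCn1ccc2cc(/C(=N/N)c3ccc(OC)c(OC)c3OC)ccc21`) differs from compound 2 in one place (amino in place of hydroxy on a double-bonded nitrogen), with amino in place of hydroxy on a double-bonded nitrogen. Going by the values given here, no measured step covers this swap, so the expected change (a 1.3-fold lower number from compound 2 to compound 3 (0.12 log units; within the scatter)) stays within the usual scatter, with no direction favoured. Compound 3 is estimated at 1500 nM (expected range 300 nM to 8000 nM).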

Compound 3, half-maximal inhibitory concentration: 2000 nM
Compound 3: the middle estimate sits 1.3-fold (0.12 log units) below what was measured, within the range that was stated.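

In this assay, putting amino in place of hydroxy on a double-bonded nitrogen gives no change at the digits printed from compound 2 to compound 3 (within the scatter). This position therefore accepts either group in this assay, and this is the only pair shown that compares two true numbers. Compound 1 alone stands at a limit of the assay, not a number: the limit of > 10000 nM in this assay, at which 1 of the 3 values shown sits.

As far as these compounds go, what stays open is how a larger group on that same nitrogen, such as dimethylamino or a benzyloxy chain, would read. From the compounds shown here alone, a carboxylic acid attached through an oxygen there is equally open.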